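A new sulfonyl substituent among rapidly removed compounds

This account rests on a few compounds, and the source may have more. Where it says the series, first, only, none or still open, it means among the compounds named here.

Measured so far in an ADME assay (liver) for metabolic stability, with Liver microsome (Homo sapiens) as the target, read by LC-MS, using microsomes and NADPH, with a stated time of 5 min, at 37 degrees C (a lower number here means slower removal, a higher number faster removal of the compound), for three compounds:
- compound 1 `CCn1c([C@@H](C)NS(=O)(=O)c2ccc(Cl)cc2)nc2ccccc21` gives > 100 mL.min-1.g-1 as a limit
- compound 2 `CCn1c([C@@H](C)NS(=O)(=O)c2cccc(C#N)c2)nc2ccc(C(F)(F)F)cc21` gives > 100 mL.min-1.g-1 as a limit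
- compound 3 `CCn1c([C@@H](C)NS(=O)(=O)c2ccc(CC(C)C)cc2)nc2ccc(C(F)(F)F)cc21` gives > 100 mL.min-1.g-1 as a limit

For compound 3 the reading is > 100 mL.min-1.g-1 which is a limit and not a number. Compound 4 `CCCn1ncc(S(=O)(=O)N[C@H](C)c2nc3ccc(C(F)(F)F)cc3n2CC)c1C` carries 5-methyl-1-propyl-1H-pyrazol-4-yl in place of 4-isobutylphenyl on the sulfonyl sulfur (5-methyl-1-propyl-1H-pyrazol-4-yl in place of 4-isobutylphenyl on a sulfonyl sulfur). Among the compounds with values here, the one measured change at this place is a step that the two limits leave unreadable from compound 2 to compound 3 and it offers no size to lean on. Within the data shown here, every value so far shares the limit of > 100 mL.min-1.g-1 in this assay, at which 3 of the 3 values shown sit, and so no direction can be read either. In this assay the expected step is therefore loose (an at least 1.2-fold lower number from compound 3 to compound 4 (0.09 log units; that floor lies within the scatter)) with no firm direction. Compound 4 is estimated at 80 mL.min-1.g-1 with an expected range from 30 mL.min-1.g-1 to 200 mL.min-1.g-1 and it may again return only a limit.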

Compound 4, intrinsic clearance in microsomes: > 100 mL.min-1.g-1
Compound 4 ended at the assay's limit (the forecaster's own chance of this, stated with the estimate: 45%); middle value at least 1.2-fold (0.09 log units) away from the limit.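

The steps from compound 2 to compound 4 and from compound 3 to compound 4 cannot be read in this assay, because the values all stop at one limit: the limit of > 100 mL.min-1.g-1 in this assay, at which 4 of the 4 values shown sit.

From the compounds shown here alone, whether the group on the sulfonyl sulfur changes the rate of removal at all stays open.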